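An aryl exchange on the ring amine nitrogen

The source may hold more compounds than are shown below. What is called first, only, known or untested is meant among the compounds shown, and "the series" means these compounds.

Compound 1 `S=c1oc(-c2ccc3c(c2)OCCO3)nn1CN1CCN(c2cccc(Cl)c2Cl)CC1`: > 50000 nM, a limit in a functional assay on HepG2 cells (Homo sapiens) for antiproliferative activity, read by MTT assay, with a stated time of 48 h; on this read-out higher numbers stand for weaker inhibition and lower numbers for stronger inhibition
Compound 2 `S=c1oc(-c2ccc3c(c2)OCCO3)nn1CN1CCN(c2cccc(Cl)c2)CC1`: > 50000 nM, a limit in this assay

Both measured compounds reach only the limit of this assay. The step that the two limits leave unreadable from compound 1 to compound 2 therefore cannot be read in size. Compound 2 stands at the limit of > 50000 nM in this assay, at which 2 of the 2 values shown sit, with no number of its own. Compound 3 `COc1ccccc1N1CCN(Cn2nc(-c3ccc4c(c3)OCCO4)oc2=S)CC1` differs from compound 2 by 2-methoxyphenyl in place of 3-chlorophenyl on an amine nitrogen in a ring. No measured step bears directly on this change, and the one step shown gives no size, so no direction can be taken from it. Compound 3 is expected to give about 50000 nM, within 20000 nM to 200000 nM, most likely again as a limit. The step of a number no higher from compound 2 to compound 3 (the limit leaves the size open) is expected to be none beyond the scatter.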

Compound 3, half-maximal inhibitory concentration: 15500 nM
For compound 3 the middle estimate is 3.2-fold (0.51 log units) above the measured one, outside the stated range (below it).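

Exchanging the aryl group on this ring nitrogen does move the read-out in this assay: 2-methoxyphenyl in place of 3-chlorophenyl gives an at least 3.2-fold lower number from compound 2 to compound 3 (0.50 log units; beyond the scatter), and in place of 2,3-dichlorophenyl it gives an at least 3.2-fold lower number from compound 1 to compound 3 (0.50 log units; beyond the scatter). Compound 1 and compound 2 remain at a limit: the limit of > 50000 nM in this assay, at which 2 of the 3 values shown sit. On these data alone, the step between those two cannot be read, so the true size of both new steps also stays open.

The compounds shown do not separate the methoxy group from its position on the phenyl ring. They also leave open whether 2-ethoxyphenyl or 2-hydroxyphenyl would keep this activity.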